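Swapping Methoxy for Chloro: What Compound 3 Might Show

This account rests on a few compounds, and the source may have more. Where it says the series, first, only, none or still open, it means among the compounds named here.

Compound 1 `COc1ccc(C(=O)/C=C/c2cc(Cl)cc(Cl)c2Oc2c([N+](=O)[O-])cc(C(F)(F)F)cc2[N+](=O)[O-])cc1` measured at 2.69 ug/mL
Compound 2 `COc1ccc(C(=O)/C=C/c2cccc(Cl)c2Oc2c([N+](=O)[O-])cc(C(F)(F)F)cc2[N+](=O)[O-])cc1` measured at 1.83 ug/mL

For the measured compounds named here, in a functional assay on MCF7 cells (Homo sapiens) for antiproliferative activity, read by MTT assay, with a stated time of 48 h (on this read-out lower numbers stand for stronger inhibition and higher numbers for weaker inhibition), compound 1 gives 2.69 ug/mL and compound 2 gives 1.83 ug/mL and the two lie within the scatter of each other, so compound 1 stands level with its only measured neighbour. Compound 3 `O=C(/C=C/c1cc(Cl)cc(Cl)c1Oc1c([N+](=O)[O-])cc(C(F)(F)F)cc1[N+](=O)[O-])c1ccc(Cl)cc1` has not yet been measured. It departs from compound 1 in one place chloro in place of methoxy on an aromatic carbon with chloro in place of methoxy on an aromatic carbon, para to a large group, so that 4-methoxyphenyl becomes 4-chlorophenyl.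

Going by the values given here, only one measured step is available, and it bears on this change only indirectly. That step, a 1.5-fold lower number from compound 1 to compound 2 (0.17 log units; within the scatter), puts hydrogen in place of chloro on an aromatic carbon and leaves the methoxy untouched. Among the compounds with values here, no measurement yet covers the loss of the methoxy itself, so no direction can be argued with confidence. Resting on that single small step, the expected change in this assay is a 1.1-fold lower number from compound 1 to compound 3 (0.03 log units; within the scatter) and nothing beyond the scatter is anticipated. In this assay compound 3 is estimated at 2.5 ug/mL with an expected range from 1 ug/mL to 6 ug/mL around it.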

Compound 3, half-maximal inhibitory concentration: 4.54 ug/mL
The estimate for compound 3 lay 1.8-fold (0.26 log units) below the measured number, and the stated range covers the measured number.
By their numbers in this assay, from the lowest: compounds 2, 1 and 3 (each within the scatter of the next, the first and the last beyond it).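

In this assay the exchange of 4-methoxyphenyl for 4-chlorophenyl gives a 1.7-fold higher number from compound 1 to compound 3 (0.23 log units; within the scatter) and so lies inside the usual variation of repeated measurements. For the compounds shown here, this is the first reading at this position, on an aromatic carbon para to a large group, since the earlier step concerned only a chloro on the other aromatic ring and left the methoxy in place. It shows that, on the core of compound 1, methoxy with its two heavy atoms and one hydrogen-bond acceptor can give way to chloro, with one heavy atom and no such acceptor, without a change that can be told from scatter, and no measurement at hand bears on any cause for this.

With only methoxy and chloro shown here, it remains open how an amine, a hydroxyl, a carboxylic acid, a longer chain such as butoxy, or plain hydrogen would read at this position. Also open, on these data alone, is whether 4-chlorophenyl would read the same way on the core of compound 2, which has hydrogen in place of one chloro.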